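The source may hold more compounds than are shown below. What is called first, only, known or untested is meant among the compounds shown, and "the series" means these compounds.

Compound 3 `O=C(CSc1nc2ccc(NC(=O)c3ccc([N+](=O)[O-])cc3)cc2s1)NCc1ccc(Cl)cc1` sits at the limit of a functional assay on HepG2 cells (Homo sapiens) for cytotoxicity, read by MTT assay, with a stated time of 48 h (on this read-out higher numbers stand for weaker inhibition and lower numbers for stronger inhibition), where it gives > 100000 nM, a limit of the assay rather than a number. Compound 1 `O=C(CSc1nc2ccc(NC(=O)c3ccc([N+](=O)[O-])cc3)cc2s1)NCc1ccccc1` gives > 100000 nM in this assay, again a limit. Compound 2 `COc1ccc(CNC(=O)CSc2nc3ccc(NC(=O)c4ccc([N+](=O)[O-])cc4)cc3s2)cc1` gives > 100000 nM in this assay, likewise a limit. Because (the limit of > 100000 nM in this assay, at which 3 of the 3 values shown sit), the steps a step that the two limits leave unreadable from compound 1 to compound 2, a step that the two limits leave unreadable from compound 1 to compound 3 and a step that the two limits leave unreadable from compound 2 to compound 3 cannot be read, and all three concern a different aromatic carbon from the one changed here. Compound 4 `COc1ccccc1C(=O)Nc1ccc2nc(SCC(=O)NCc3ccc(Cl)cc3)sc2c1` differs from compound 3 as follows: 2-methoxyphenyl in place of 4-nitrophenyl on a carbonyl carbon. Among the measured compounds shown here, no measured step touches this position, so the numbers give no direction for the change. Compound 4 is therefore expected to give about 100000 nM in this assay, within 30000 nM to 300000 nM, a step of a number no higher from compound 3 to compound 4 (the limit leaves the size open) that is expected to appear again only as a limit.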

Compound 4, half-maximal inhibitory concentration: 600 nM
Compound 4: the middle estimate sits 170-fold (2.22 log units) above what was measured; the whole stated range lies above it.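

In this assay, the group on this carbonyl carbon clearly matters: 2-methoxyphenyl in place of 4-nitrophenyl gives an at least 160-fold lower number from compound 3 to compound 4 (2.22 log units; beyond the scatter). The earlier steps cannot be read, so this is the first change here with a readable size, and the reason lies in the shared limit: the limit of > 100000 nM in this assay, at which 3 of the 4 values shown sit.

The compounds shown leave open whether gaining the methoxy or losing the nitro drives this step. They also leave open how an unsubstituted phenyl, or a phenyl carrying an amine or a carboxylic acid, would read at this position.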